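This account rests on a few compounds, and the source may have more. Where it says the series, first, only, none or still open, it means among the compounds named here.

Compound 1 `CCOc1nc2ccccn2c(=N)c1S(=O)(=O)c1ccccc1` gives 12 nM in an assay on HeLa cells for displacement of a labelled ligand from 5-hydroxytryptamine receptor 6 (Homo sapiens) (on this read-out lower numbers stand for stronger inhibition and higher numbers for weaker inhibition), the lowest of the two numbers recorded; compound 2 `CSc1nc2ccccn2c(=O)c1S(=O)(=O)c1ccccc1` gives 52 nM in this assay, a higher number beyond the usual scatter. Compound 3 `N=c1c(S(=O)(=O)c2ccccc2)c(NCCO)nc2ccccn12` is not yet measured. It differs from compound 1 by a change in one place: (2-hydroxyethyl)amino in place of ethoxy on an aromatic carbon. Among the compounds with values here, no measured pair shows this change, so the direction rests on expectation alone. For compound 3 the step from compound 1 is expected to be a 1.5-fold higher number from compound 1 to compound 3 (0.18 log units; within the scatter), a size that may not go beyond the scatter. Compound 3 is accordingly estimated at 18 nM, within a range of 5 nM to 70 nM.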

Compound 3, half-maximal inhibitory concentration: 42 nM
For compound 3 the middle estimate is 2.3-fold (0.37 log units) below the measured one; the range from low to high includes it.
By their numbers in this assay, from the lowest: compound 1; then compounds 3 and 2 (each within the scatter of the next).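

In this assay, within the data shown here, (2-hydroxyethyl)amino in place of ethoxy on this aromatic carbon gives a 3.5-fold higher number from compound 1 to compound 3 (0.54 log units; beyond the scatter), the first measured step at this position. The change costs some inhibition but does not abolish it, as compound 3 still gives 42 nM in this series. No measured evidence accounts for the step. The compounds shown do not separate the contribution of the ring-bound nitrogen from that of the terminal hydroxyl. An unsubstituted ethylamino group or a longer chain such as 3-hydroxypropylamino would be needed to tell them apart.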